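A few compounds are considered here, and "the series" means these few. Any claim that something is new, unique, unknown or untested is made for them only; others in the source may bear on it.

Working notes on the series

Compound 1 `CN(C)CCC(OC(=O)NCc1ccccc1)c1ccc(Cl)cc1` is the reference carbamate; in an assay on NIH3T3 cells with Urotensin-2 receptor (Homo sapiens) as the target (a lower number here means that less compound is needed, a higher number that more compound is needed for the effect), compound 1 gives 2140 nM. Compound 2 `COc1cccc(NC(=O)OC(CCN(C)C)c2ccc(Cl)cc2)c1` carries the change (3-methoxyphenyl in place of benzyl on an amide-type nitrogen); in this assay compound 2 gives 1120 nM, and the step of a 1.9-fold lower number from compound 1 to compound 2 (0.28 log units; within the scatter) does not leave the scatter, so no order between compound 1 and compound 2 can be read from it.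

Compound 3 `CN(C)CCC(NC(=O)NCc1ccccc1)c1ccc(Cl)cc1` is the urea counterpart; in this assay compound 3 gives 2000 nM. The difference between the core of compound 3 and the core of compound 1 is not broken down here; their values sit within the scatter of each other, as do those of compound 3 and compound 2.

Compound 4 `COc1cccc(NC(=O)NC(CCN(C)C)c2ccc(Cl)cc2)c1` is not yet measured. It differs from compound 3 by 3-methoxyphenyl in place of benzyl on an amide-type nitrogen, the same change as that from compound 1 to compound 2, at the same place. The step from compound 3 to compound 4 in this assay is expected to be a 1.8-fold lower number from compound 3 to compound 4 (0.26 log units; within the scatter), resting on the earlier step of a 1.9-fold lower number from compound 1 to compound 2 (0.28 log units; within the scatter) and on the shared read-out of compound 3 at 2000 nM. For compound 4 the estimate in this assay is 1100 nM, expected between 500 nM and 2500 nM.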

Compound 4, half-maximal effective concentration: 1350 nM
The estimate for compound 4 lay 1.2-fold (0.09 log units) below the measured number; low and high end bracket the measured number.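

On the core of compound 3, 3-methoxyphenyl in place of benzyl on an amide-type nitrogen gives in this assay a 1.5-fold lower number from compound 3 to compound 4 (0.17 log units; within the scatter), so no order between these two compounds can be read from it. Set beside the step on the core of compound 1, the change reads the same on both cores: the same change on two cores in this assay, a 1.9-fold lower number (0.28 log units; within the scatter) from compound 1 to compound 2 and a 1.5-fold lower number (0.17 log units; within the scatter) from compound 3 to compound 4, 1.3-fold (0.11 log units) apart, within the scatter of two such steps

This agreement shows that nothing in these four compounds separates the carbamate from the urea in how the change carries over, but each step on its own stays within the scatter, so it does not show that the change has any effect on either core, and two cores are no basis for a rule across the series.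

Open, from the compounds shown here alone, is whether a change with a step beyond the scatter would carry over between these cores in the same way. Groups such as a plain phenyl or a phenethyl chain on that nitrogen, or a primary amine in place of the dimethylamino group, would test this further.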